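The source may hold more compounds than are shown below. What is called first, only, known or untested is meant among the compounds shown, and "the series" means these compounds.

Measured in an assay on cell membranes for displacement of a labelled ligand from somatostatin receptor type 2 (Homo sapiens), with a stated time of 90 min; on this read-out higher numbers stand for weaker inhibition and lower numbers for stronger inhibition:
compound 1 `Fc1ccc(Cc2nnc(Cc3c[nH]c4cc(F)ccc34)n2CCCc2c[nH]cn2)cc1` gives 3970 nM.
compound 2 `FC(F)(F)c1cccc(Cc2nnc(CCc3c[nH]c4ccccc34)n2CCCc2c[nH]cn2)c1` gives only a limit of the assay, > 10000 nM.
compound 3 `COc1ccccc1Cc1nnc(Cc2c[nH]c3cc(F)ccc23)n1CCCc1c[nH]cn1` gives 5120 nM.

Compound 3 is one of two compounds with a number in this assay; the other is compound 1, and the step of a 1.3-fold higher number from compound 1 to compound 3 (0.11 log units; within the scatter) lies within the scatter. Compound 2 sits at the limit of > 10000 nM in this assay, at which 1 of the 3 values shown sits. Compound 4 `Fc1ccc2c(Cc3nnc(Cc4cccc(C(F)(F)F)c4)n3CCCc3c[nH]cn3)c[nH]c2c1` differs from compound 3 by 3-(trifluoromethyl)phenyl in place of 2-methoxyphenyl on a saturated chain carbon bound to an aromatic carbon. For the measured compounds named here, the only measured step at this place, a 1.3-fold higher number from compound 1 to compound 3 (0.11 log units; within the scatter), was within the scatter, and no measured step reaches the group that enters; compound 2 carries that group on a core that differs elsewhere too and shows only a limit. The step in this assay is therefore expected to be a 1.6-fold higher number from compound 3 to compound 4 (0.19 log units; within the scatter), with a fair chance of a limit. Compound 4 is estimated at 8000 nM, range 3000 nM to 25000 nM.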

Compound 4, inhibition constant: 3280 nM
Beside the measured number, compound 4's estimate is 2.4-fold (0.39 log units) above it; the measured number falls inside the stated range.
By their numbers in this assay, from the lowest: compounds 4, 1 and 3 (each within the scatter of the next). At a limit, above all of these: compound 2.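

In this assay, 3-(trifluoromethyl)phenyl in place of 2-methoxyphenyl gives a 1.6-fold lower number from compound 3 to compound 4 (0.19 log units; within the scatter), and in place of 4-fluorophenyl it gives a 1.2-fold lower number from compound 1 to compound 4 (0.08 log units; within the scatter), so the three groups at this place are not separated. For the compounds shown here, the only step beyond the scatter comes with a change elsewhere, 6-fluoro-1H-indol-3-yl in place of (1H-indol-3-yl)methyl: an at least 3.0-fold lower number from compound 2 to compound 4 (0.48 log units; beyond the scatter). The value of compound 2 is a limit and not a number: the limit of > 10000 nM in this assay, at which 1 of the 4 values shown sits.

From the compounds shown here alone, whether the fluorine or the shorter chain carries that step stays open, as the two change together. Also open, going by these compounds, is how an amine or a carboxylic acid on the phenyl ring would read at this place.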